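Amide to urea on the shared core: expectation for compound 4

The source may report more compounds than this note shows. Statements on the series, on what has been measured and on what is new or still open speak of the compounds shown alone.

Compound 1 `COc1cc(-c2nn(-c3cccc(NC(=O)c4cccc(C(F)(F)F)c4)c3)cc2-c2ccncc2)ccc1Cl` carries an amide on the shared core. In a functional assay on PC-3 cells (Homo sapiens) for inhibition, read by sulforhodamine B assay, with a stated time of 48 h (on this read-out lower numbers stand for stronger inhibition of growth and higher numbers for weaker inhibition of growth), compound 1 gives only a limit, > 50000 nM, and no number. The limit is the limit of > 50000 nM in this assay, at which 1 of the 3 values shown sits, so the standing of compound 1 in this assay is known only as a bound, not as a value. Going by the values given here, compound 2 `COc1cc(-c2nn(-c3cccc(NC(=O)Nc4cccc(C(F)(F)F)c4)c3)cc2-c2ccncc2)ccc1Cl` differs from it by the urea linker and in this assay gives 2510 nM; the step of an at least 19-fold lower number from compound 1 to compound 2 (1.29 log units; beyond the scatter) is the one measured change that bears on the case. Compound 3 `O=C(Nc1cccc(-n2cc(-c3ccncc3)c(-c3ccc(Cl)c(O)c3)n2)c1)Nc1cc(C(F)(F)F)cc(C(F)(F)F)c1`, also a urea but with a different aryl group and a hydroxyl in place of the methoxy on the shared core, gives 4370 nM in this assay.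

Compound 4 `COc1cc(-c2nn(-c3cccc(NC(=O)Nc4ccc(Cl)c(C(F)(F)F)c4)c3)cc2-c2ccncc2)ccc1Cl` differs from compound 1 by (4-chloro-3-(trifluoromethyl)phenyl)amino in place of 3-(trifluoromethyl)phenyl on a carbonyl carbon. This is the same amide-to-urea exchange as from compound 1 to compound 2, with an additional chlorine on the entering aryl ring. The step from compound 1 to compound 2 was large and beyond the scatter, and a step of similar size in the same direction is expected here, as an at least 27-fold lower number from compound 1 to compound 4 (1.44 log units; beyond the scatter). Compound 4 is therefore estimated at 1800 nM in this assay, within 500 nM to 6000 nM.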

Compound 4, concentration for total growth inhibition: 2450 nM
Compound 4: the middle estimate sits 1.4-fold (0.13 log units) below what was measured; the measured number falls inside the stated range.
By their numbers in this assay, from the lowest: compounds 4, 2 and 3 (each within the scatter of the next). At a limit, above all of these: compound 1.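

In this assay, going by these compounds alone, the exchange of amide for urea on the carbonyl carbon now holds for a second entering group, (4-chloro-3-(trifluoromethyl)phenyl)amino, with an at least 20-fold lower number from compound 1 to compound 4 (1.30 log units; beyond the scatter), so this large step no longer rests on the single pair that carries the unsubstituted-by-chloro 3-(trifluoromethyl)phenyl ring. The chlorine itself can now be read apart from the linker: a 1.0-fold lower number from compound 2 to compound 4 (0.01 log units; within the scatter), which places chloro in place of hydrogen on an aromatic carbon within the scatter, and the step seen from the amide therefore tracks the urea and not the added chlorine. Compound 1 remains a limit, so both steps from it are bounds and their true size stays unknown: the limit of > 50000 nM in this assay, at which 1 of the 4 values shown sits.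

The compounds shown leave open whether a urea keeps this level with a different linker, such as a thiourea or a sulfonamide, or with a different group on the entering ring, such as a methoxy group, an amine or a carboxylic acid. Compound 3 differs from the other ureas in more than one place, so the separate contributions of its hydroxyl and its second trifluoromethyl group also stay unresolved in this assay.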